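A few compounds are considered here, and "the series" means these few. Any claim that something is new, unique, unknown or untested is made for them only; others in the source may bear on it.

Of the compounds shown here, two carry numbers so far. Compound 1 `COc1ccc(-c2nc(C)c(C(=O)CSc3nc(N)c(C#N)c(-c4ccccc4)n3)s2)cc1` gives 5.25% in a functional assay on U-87MG ATCC cells for antiproliferative activity against U-87 MG (Homo sapiens), read by MTT assay, with a stated time of 48 h, tested at 100 uM; a lower number here means a stronger effect, a higher number a weaker effect of the compound at the concentration tested. Compound 2 `COc1ccc(-c2nc(C)c(C(=O)CSc3nc(-c4ccc(Cl)cc4)c(C#N)c(=O)[nH]3)s2)cc1` gives 2.85% in this assay. Going by the values given here, compound 2 stands on the lower of the two numbers, though compound 1 lies within the scatter of it, so the two values show no separation between these compounds. Among the compounds with values here, no step between measured compounds has been established in this set. Compound 3 `COc1ccc(-c2nc(C)c(C(=O)CSc3nc(-c4cccc(OC)c4)c(C#N)c(=O)[nH]3)s2)cc1` is the next member, not yet measured in this assay. Relative to compound 2 the change is 3-methoxyphenyl in place of 4-chlorophenyl on an aromatic carbon. Nothing measured in the series bears on this exchange, and both measured values sit close to the bottom of the scale, so no step beyond the scatter is expected. The expected step from compound 2 to compound 3 in this assay is a number 2.2 percentage points higher from compound 2 to compound 3 (within the scatter). For compound 3 the estimated value in this assay is 5%, with a range from 0% to 16%.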

Compound 3, a percentage reported as activity, at one concentration (the size of the read-out at that concentration, not a potency): 12.4%
The estimate for compound 3 lay 7.4 percentage points below the measured number; low and high end bracket the measured number.
By their numbers in this assay, from the lowest: compounds 2, 1 and 3 (each within the scatter of the next).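

Going by these compounds alone, the first readable step at this position, on the aromatic carbon ortho to a cyano group, comes from exchanging 4-chlorophenyl for 3-methoxyphenyl: in this assay the step is a number 9.6 percentage points higher from compound 2 to compound 3 (within the scatter). The exchange alters both the substituent and its place on the phenyl ring, yet this step gives no separation between the two compounds, so neither alteration can be read on its own. No measurement at hand offers an explanation for the size of this step.

On these data alone, whether 4-methoxyphenyl or 3-chlorophenyl at this carbon would separate the substituent from its place on the phenyl ring remains open. Also open, as far as these compounds go, is whether an amine or a carboxylic acid on that phenyl ring, or a longer chain in place of methoxy, would give a step beyond the scatter.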